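Adding One Carbon to a Long Saturated Chain

The source may hold more compounds than are shown below. What is called first, only, known or untested is meant among the compounds shown, and "the series" means these compounds.

Compound 1, `CCCCCCCCCCCCCCCCOC1=C(O)OC(C(O)CO)C1=O`: 6800 nM
Compound 2, `CCCCCCCCCCCCCCCCCOC1=C(O)OC(C(O)CO)C1=O`: 11000 nM
Compound 3, `CCCCCCCCCCCCCCCCCCCCOC1=C(O)OC(C(O)CO)C1=O`: 4700 nM

These three compounds share one core and differ only in the length of a saturated chain attached to it. All three were measured in a functional assay (brain) for inhibition, with Rattus norvegicus as the target; on this read-out lower numbers stand for stronger inhibition and higher numbers for weaker inhibition. Compound 1 and compound 2 differ by methyl in place of hydrogen on a saturated chain carbon, ten or more bonds along the chain from an oxygen on an unsaturated carbon, and that step gives a 1.6-fold higher number from compound 1 to compound 2 (0.21 log units; within the scatter). From compound 2 to compound 3 the step is a 2.3-fold lower number from compound 2 to compound 3 (0.37 log units; beyond the scatter), while from compound 1 to compound 3 it is a 1.4-fold lower number from compound 1 to compound 3 (0.16 log units; within the scatter).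

Compound 4, `CCCCCCCCCCCCCCCCCCCCCOC1=C(O)OC(C(O)CO)C1=O`, has not yet been measured. It differs from compound 3 by methyl in place of hydrogen on a saturated chain carbon, ten or more bonds along the chain from an oxygen on an unsaturated carbon. This is the same change that turns compound 1 into compound 2, made at the same place; the two starting points themselves differ by butyl in place of hydrogen on a saturated chain carbon, ten or more bonds along the chain from an oxygen on an unsaturated carbon. Because the earlier step of a 1.6-fold higher number from compound 1 to compound 2 (0.21 log units; within the scatter) stayed within the scatter of repeated measurements, the number for compound 4 is expected to shift only slightly, by about a 1.3-fold higher number from compound 3 to compound 4 (0.11 log units; within the scatter). Compound 4 is therefore estimated at 6000 nM, most likely falling between 2500 nM and 15000 nM.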

Compound 4, half-maximal inhibitory concentration: 11000 nM
Compound 4: middle estimate off by 1.8-fold (0.26 log units), on the low side; the measured number falls inside the stated range.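

In this assay, methyl in place of hydrogen on the chain gives a 2.3-fold higher number from compound 3 to compound 4 (0.37 log units; beyond the scatter), and this step agrees with the same change made earlier on a shorter chain, since the gap between them stays within the scatter: the same change on two cores in this assay, a 1.6-fold higher number (0.21 log units; within the scatter) from compound 1 to compound 2 and a 2.3-fold higher number (0.37 log units; beyond the scatter) from compound 3 to compound 4, 1.4-fold (0.16 log units) apart, within the scatter of two such steps

Butyl in place of hydrogen gives no change at the digits printed from compound 2 to compound 4 (within the scatter), pentyl in place of hydrogen gives a 1.6-fold higher number from compound 1 to compound 4 (0.21 log units; within the scatter), and the butyl change also agrees across its two starting points: the same change on two cores in this assay, a 1.4-fold lower number (0.16 log units; within the scatter) from compound 1 to compound 3 and no change at the digits printed (within the scatter) from compound 2 to compound 4, 1.4-fold (0.16 log units) apart, within the scatter of two such steps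

So these changes carried over from one core to the other about as far as this assay can tell, but two pairs per change are very little evidence, and they do not show a fixed step size or a steady trend with chain length, as the numbers rise and fall as the chain grows.

From the compounds shown here alone, whether a much shorter chain, such as butyl alone, would follow the same steps remains open. So does the effect of a chain carrying an amine or a carboxylic acid.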